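The source may report more compounds than this note shows. Statements on the series, on what has been measured and on what is new or still open speak of the compounds shown alone.

Compound 1 `CC(=O)NC(c1cccs1)c1cc(Cl)c2cccnc2c1O`: 1000 nM
Compound 2 `CCC(=O)NC(c1cccs1)c1cc(Br)c2cccnc2c1O`: 14000 nM

In an assay for inhibition of Polyunsaturated fatty acid lipoxygenase ALOX12 (Homo sapiens), read by spectrophotometry (a higher number here means a weaker inhibitor, a lower number a stronger inhibitor), compound 1 gives 1000 nM and compound 2 gives 14000 nM, the higher of the two numbers, with a gap between them that lies beyond the usual scatter. Compound 3 `CCC(=O)NC(c1ccco1)c1cc(Br)c2cccnc2c1O` is not yet measured; it differs from compound 2 by furan-2-yl in place of thiophen-2-yl on a saturated chain carbon bound to an amide-type nitrogen and an aromatic carbon. Within the data shown here, exchanging one five-membered aromatic ring for another is a small change, and no measured pair shows what it does here. The step of a 1.1-fold higher number from compound 2 to compound 3 (0.03 log units; within the scatter) is therefore expected to be none beyond the scatter. Compound 3 is estimated at 15000 nM, within 5000 nM to 50000 nM.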

Compound 3, half-maximal inhibitory concentration: 2000 nM
For compound 3 the middle estimate is 7.5-fold (0.88 log units) above the measured one; measured number outside the range, below it.
By their numbers in this assay, from the lowest: compounds 1 and 3 (each within the scatter of the next); then compound 2.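

In this assay, furan-2-yl in place of thiophen-2-yl on a saturated chain carbon bound to an amide-type nitrogen and an aromatic carbon gives a 7.0-fold lower number from compound 2 to compound 3 (0.85 log units; beyond the scatter), so this position responds to the exchange. The two rings have the same counts of heavy atoms and hydrogen-bond acceptors, and oxygen replacing sulfur is the only difference between them. No measurement here explains the change. Still open, going by these compounds, is whether the same exchange would have a similar effect in compound 1, which differs from compound 2 in two places. Also open, on these data alone, is what a phenyl ring would do at this position.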